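Vinyl sulfone indoles: from an acetyl to a nitrile

A few compounds are considered here, and "the series" means these few. Any claim that something is new, unique, unknown or untested is made for them only; others in the source may bear on it.

Compound 1 `CCOC(=O)C(=Cc1c(-c2ccccc2)[nH]c2ccccc12)C(=O)OCC`: 4700 nM
Compound 2 `COc1ccc(-c2[nH]c3ccc(OC)cc3c2/C=C(\C#N)S(=O)(=O)c2ccccc2)cc1`: 9000 nM
Compound 3 `CC(=O)/C(=C\c1c(-c2ccccc2)[nH]c2ccccc12)S(=O)(=O)c1ccccc1`: 1400 nM

Three compounds built on a shared core were tested in a functional assay on SK-MEL-2 cells (Homo sapiens) for inhibition, read by sulforhodamine B assay, with a stated time of 48 h; on this read-out lower numbers stand for stronger inhibition of growth and higher numbers for weaker inhibition of growth. Compound 3 gives 1400 nM, the lowest number of the three; compound 1 stands at a higher number, beyond the scatter, and compound 2 lies further still, also beyond the scatter. On these numbers compound 3 is the most potent of the set.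

Compound 4 `N#C/C(=C\c1c(-c2ccccc2)[nH]c2ccccc12)S(=O)(=O)c1ccccc1` has not yet been measured in this assay. It differs from compound 3 in one place: cyano in place of acetyl on a double-bonded chain carbon bound to a double-bonded chain carbon and a sulfonyl sulfur. Among the compounds with values here, no step of exactly this kind is found among the measured compounds, so the size of the step cannot be read off from them. Compound 2 carries a cyano at this place and gives 9000 nM, but it also differs from compound 3 elsewhere, so only its value can be noted. The expectation is a modest weakening, possibly within the scatter; the estimated step of a 1.8-fold higher number from compound 3 to compound 4 (0.25 log units; within the scatter) reflects this. Compound 4 is therefore expected to give about 2500 nM in this assay, with a range from 800 nM to 8000 nM.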

Compound 4, concentration for 50% growth inhibition: 12700 nM
Compound 4: the middle estimate sits 5.1-fold (0.71 log units) below what was measured; measured number above the stated range.
By their numbers in this assay, from the lowest: compound 3; then compounds 1, 2 and 4 (each within the scatter of the next, the first and the last beyond it).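

Replacing acetyl with cyano on a double-bonded chain carbon bound to a double-bonded chain carbon and a sulfonyl sulfur gives a 9.1-fold higher number from compound 3 to compound 4 (0.96 log units; beyond the scatter) in this assay, so growth inhibition in these cells depends on which group this position carries. Within the data shown here, none of the earlier compounds formed a pair differing only here, and this is the first change at this position whose size can be read with the rest of the structure held constant. Nothing available accounts for the size of this step.

Going by these compounds, whether other groups at this place, such as a carboxylic acid, a primary amide or a longer acyl chain, would fall nearer compound 3 or compound 4 remains open. Also open, on these data alone, is whether the same change would give a step of similar size with substituents elsewhere on the shared core.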